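Alpha-ketooxazole series: terminal chain groups on the oxazole substituent

A few compounds are considered here, and "the series" means these few. Any claim that something is new, unique, unknown or untested is made for them only; others in the source may bear on it.

Measured so far in an assay for inhibition of Fatty-acid amide hydrolase 1 (Rattus norvegicus), using a Dixon plot; on this read-out lower numbers stand for stronger inhibition and higher numbers for weaker inhibition:
compound 1 `N#C/C=C/c1ccc(-c2cnc(C(=O)CCCCCCc3ccccc3)o2)nc1` gives 2.1 nM
compound 2 `C[S+]([O-])/C=C/c1ccc(-c2cnc(C(=O)CCCCCCc3ccccc3)o2)nc1` gives 3 nM
compound 3 `CSC(=O)CCCCc1cnc(C(=O)CCCCCCc2ccccc2)o1` gives 1.8 nM

Compound 3 carries the lowest of the three numbers, but its gaps to compound 1 and compound 2 both lie within the scatter, so no order among the three can be read. For the measured compounds named here, the only single-point step measured, a 1.4-fold higher number from compound 1 to compound 2 (0.15 log units; within the scatter), sits on a different side chain and changed nothing beyond the scatter.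

Compound 4 `O=C(CCCCCCc1ccccc1)c1ncc(CCCCCBr)o1` differs from compound 3 by bromomethyl in place of (methylsulfanyl)carbonyl on a saturated chain carbon, four bonds along the chain from an aromatic carbon. Going by the values given here, no measured step bears on this exchange; the one step known is on another chain. The estimate therefore rests on compound 3 alone: compound 4 is expected at 6 nM (range 1.5 nM to 25 nM), a step of a 3.3-fold higher number from compound 3 to compound 4 (0.52 log units; beyond the scatter).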

Compound 4, inhibition constant: 6.1 nM
Beside the measured number, compound 4's estimate is 1.0-fold (0.01 log units) below it, within the range that was stated.
By their numbers in this assay, from the lowest: compounds 3, 1 and 2 (each within the scatter of the next); then compound 4.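

For the compounds shown here, at the chain end, bromomethyl in place of (methylsulfanyl)carbonyl gives the first step that lies beyond the scatter in this assay (a 3.4-fold higher number from compound 3 to compound 4 (0.53 log units; beyond the scatter)). The terminal group on this chain therefore registers in the read-out, although the step is modest. Nothing measured here accounts for the step.

Open, as far as these compounds go, is whether a carboxylic acid or an amine at this chain end would stay with compound 3 or move as compound 4 does. Also open, from the compounds shown here alone, is how a longer chain carrying bromine would read.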